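Azetidinyl quinolone series: solubility notes, compound 2 to compound 3

The source may report more compounds than this note shows. Statements on the series, on what has been measured and on what is new or still open speak of the compounds shown alone.

Measured so far:
- compound 1 `C[C@H]1[C@H](N)CN1c1c(F)cc2c(=O)c(C(=O)O)cn(C3CC3)c2c1Cl`: 12 ug/mL
- compound 2 `CN(C)C1(C)CN(c2c(F)cc3c(=O)c(C(=O)O)cn(C4CC4)c3c2F)C1`: 23.6 ug/mL

In a physicochemical assay for solubility, at pH 7.4 (a lower number here means a less soluble compound, a higher number a more soluble compound), compound 2 gives the higher of the two numbers, but its gap to compound 1 lies within the scatter, so the two are not separated. Compound 3 `CN[C@H]1CN(c2c(F)cc3c(=O)c(C(=O)O)cn(C4CC4)c3c2F)[C@@H]1C` has not yet been measured. It differs from compound 2 in one place: a group of 7 heavy atoms (5 carbon, 2 nitrogen; one four-membered non-aromatic ring with 1 hetero atom) in place of a group of 8 heavy atoms (6 carbon, 2 nitrogen; one four-membered non-aromatic ring with 1 hetero atom), on an aromatic carbon. The entering group carries one hydrogen-bond donor where the leaving group had none, and it resembles the group of compound 1 in that respect, yet compound 1 and compound 2 already sit within the scatter of each other in this assay. With nothing more to go on, the step from compound 2 to compound 3 is expected to stay within the scatter, if anything leaning slightly lower: a 1.4-fold lower number from compound 2 to compound 3 (0.14 log units; within the scatter). Compound 3 is estimated at 17 ug/mL, with a range from 6 ug/mL to 50 ug/mL.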

Compound 3, solubility: 13.1 ug/mL
Compound 3: the middle estimate sits 1.3-fold (0.11 log units) above what was measured; low and high end bracket the measured number.
By their numbers in this assay, from the lowest: compounds 1, 3 and 2 (each within the scatter of the next).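

At this position, on an aromatic carbon ortho to two fluoro groups, replacing the 3-(dimethylamino)-3-methylazetidin-1-yl group gives a 1.8-fold lower number from compound 2 to compound 3 (0.26 log units; within the scatter) in this assay. This is the only one-place comparison shown, and it does not separate the two compounds, even though the entering group carries a hydrogen-bond donor where the leaving group has none, along with 2 defined stereocentres. Nothing available explains the result or links it to any feature of either group.

The entering group differs in heavy-atom count, donor count and defined stereocentres all at once, so this pair cannot assign any effect to one of these features alone. As far as these compounds go, how a primary amine or a longer aminoalkyl chain at this position would read in this assay remains open.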